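A few compounds are considered here, and "the series" means these few. Any claim that something is new, unique, unknown or untested is made for them only; others in the source may bear on it.

Measured compounds:
- compound 1 `Cc1nn(-c2ncnc3nc[nH]c23)c2c1C(C(=O)NCc1ccc(F)cc1)CC(=O)N2`; in a functional assay on HEK293 cells for agonist activity at G-protein coupled receptor 39 (Homo sapiens), read by scintillation proximity assay and inositol phosphate accumulation, with a stated time of 75 min, in the presence of a further agent that is not named here (a lower number here means that less compound is needed, a higher number that more compound is needed for the effect), compound 1 gives 4 nM
- compound 2 `Cc1nn(-c2ncnc3nc[nH]c23)c2c1C(c1ccc(OC(C)C)cc1)CC(=O)N2`; in this assay compound 2 gives 18 nM

Of the two numbers at hand, compound 2 has the higher one, and its distance from compound 1 lies beyond the usual scatter of repeated measurements, so compound 2 is the weaker agonist of the pair on these data.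

Compound 3 `Cc1nn(-c2ncnc3nc[nH]c23)c2c1C(OCCn1cccn1)CC(=O)N2` is the next compound of the series and has not yet been measured. Its difference from compound 2 is 2-(1H-pyrazol-1-yl)ethoxy in place of 4-isopropoxyphenyl on a saturated ring carbon. For the measured compounds named here, no step of this kind between measured compounds is available, so the size of the change can only be guessed from the two values shown. Going by the values given here, the replaced group is the larger of the two and the only one carrying an aromatic ring of carbon only; the entering group is smaller and brings more hydrogen-bond acceptors. In the absence of a comparable measured step, a moderate increase in the number, beyond the scatter but not large, is expected for compound 3, meaning a step of a 2.5-fold higher number from compound 2 to compound 3 (0.40 log units; beyond the scatter) in this assay.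

For compound 3 the estimated value in this assay is 45 nM, with a range from 12 nM to 180 nM.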

Compound 3, half-maximal effective concentration: 16 nM
Compound 3: the middle estimate sits 2.8-fold (0.45 log units) above what was measured; measured number inside the range.
By their numbers in this assay, from the lowest: compound 1; then compounds 3 and 2 (each within the scatter of the next).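

In this assay, 2-(1H-pyrazol-1-yl)ethoxy in place of 4-isopropoxyphenyl on a saturated ring carbon gives a 1.1-fold lower number from compound 2 to compound 3 (0.05 log units; within the scatter), so the two groups cannot be told apart at this position. A six-membered aromatic ring of carbon only is therefore not required here, since compound 3 carries a five-membered aromatic ring with 2 hetero atoms instead and still gives 16 nM, although the two compounds shown with such different groups are only a single pair. Nothing at hand accounts for how closely the two groups match in this read-out.

Still open, as far as these compounds go, is whether any aromatic ring is needed on this carbon, which a plain methoxy group or an ethoxy chain ending in an amine or a carboxylic acid would test. Also open, from the compounds shown here alone, is how a longer chain ending in the same pyrazole would compare with compound 3, and whether such a group could approach the lower number of compound 1, at 4 nM in this assay.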